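The compounds below may be only part of what the source reports. "The series", "measured", "known", "first", "only" and "open" are said of these compounds alone.

Measured so far in a functional assay on the whole organism (strain Swiss) with Mus musculus as the target, in the maximal electroshock model, with a stated time of 1 h, at a dose of 300 mg/kg by the intraperitoneal route; a lower number here means a weaker effect, a higher number a stronger effect of the compound at the dose given:

compound 1, `CC(C(=O)N1CCN(c2ccc(Cl)cc2)CC1)N1C(=O)CCC1=O`, gives 0%
compound 2, `CC(C(=O)N1CCN(c2cccc(F)c2)CC1)N1C(=O)CCC1=O`, gives 75%
compound 3, `CC(C(=O)N1CCN(c2ccccc2Cl)CC1)N1C(=O)CCC1=O`, gives 25%

All three share one core and differ only in the ring attached to the amine nitrogen of the piperazine-like ring. Compound 3 stands second highest of the three numbers: compound 1 is nearest, with a number 25 percentage points higher from compound 1 to compound 3 (beyond the scatter), and compound 2 is furthest, with a number 50 percentage points lower from compound 2 to compound 3 (beyond the scatter).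

Compound 4, `CC(C(=O)N1CCN(c2cccc(Cl)c2)CC1)N1C(=O)CCC1=O`, has not yet been measured. It differs from compound 3 in one place, (3-chlorophenyl in place of 2-chlorophenyl on an amine nitrogen in a ring).

Going by the values given here, two measured steps bear on this. The step of a number 50 percentage points lower from compound 2 to compound 3 (beyond the scatter) shows that a 3-substituted ring outperformed the 2-chlorophenyl by a large margin, though with fluorine rather than chlorine. The step of a number 75 percentage points higher from compound 1 to compound 2 (beyond the scatter) shows a large gain on moving from 4-chlorophenyl to 3-fluorophenyl. Compound 4 keeps the chlorine but moves it to the 3-position, so a rise is expected, but a smaller one than for compound 2, since no direct chlorine-for-fluorine comparison exists. The expected step is a number 25 percentage points higher from compound 3 to compound 4 (beyond the scatter). For compound 4 the estimated value is 50%, between 20% and 80%.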

Compound 4, a percentage reported as activity, at one dose (the size of the read-out at that dose, not a potency): 75%
Estimate against measurement, compound 4: 25 percentage points below; the measured number falls inside the stated range.
By their numbers in this assay, from the lowest: compound 1; then compound 3; then compounds 2 and 4 (each within the scatter of the next).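

With the chlorine kept and only its place on the ring changed, a number 50 percentage points higher from compound 3 to compound 4 (beyond the scatter) in this assay, and a number 75 percentage points higher from compound 1 to compound 4 (beyond the scatter). Among these three chlorophenyl compounds, the 3-chlorophenyl of compound 4 therefore gives the highest number, so the place of the chlorine alone accounts for a large difference. The earlier 3-substituted compound carried fluorine, and the swap of halogen at this place now shows no change at the digits printed from compound 2 to compound 4 (within the scatter), so this pair of halogens is not told apart here. Nothing available explains why the place of the chlorine matters so much.

From the compounds shown here alone, it remains open whether a methoxy or a trifluoromethyl group in place of the chlorine of compound 4 would keep this effect. Going by these compounds, each number also comes from a single dose, so the relative potency of compound 2 and compound 4 stays unknown.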